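Acetylating the hydroxymethyl of compound 1

The source may report more compounds than this note shows. Statements on the series, on what has been measured and on what is new or still open speak of the compounds shown alone.

Values in a functional assay on RAW264.7 cells (Mus musculus), read by Griess assay, with a stated time of 15 min; a higher number here means a weaker inhibitor, a lower number a stronger inhibitor:
- Compound 1 `C[C@@H]1C[C@H](O)C2=C(CO)C(=O)O/C2=C/[C@@]2(C)CC[C@]1(O)O2`: 24700 nM
- Compound 2 `CO[C@]12CC[C@](C)(/C=C3/OC(=O)C(CO)=C3[C@@H](O)C[C@H]1C)O2`: 28100 nM
- Compound 3 `C=C(C)C(=O)O[C@H]1C[C@@H](C)[C@]2(OC)CC[C@](C)(/C=C3/OC(=O)C(COC(C)=O)=C31)O2`: 1500 nM

Compound 1 sits with compound 2 at the weak end of this small set, while compound 3 reads clearly lower. Compound 4 `CC(=O)OCC1=C2/C(=C\[C@@]3(C)CC[C@](O)(O3)[C@H](C)C[C@@H]2O)OC1=O` changes compound 1 in one place, hydroxymethyl to acetoxymethyl: acetyl in place of hydrogen on an oxygen on a saturated carbon. Going by the values given here, the only measured single change, a 1.1-fold higher number from compound 1 to compound 2 (0.06 log units; within the scatter), adds a methyl, not an acetyl, and stays within the scatter. Compound 3 also carries acetoxymethyl and gives 1500 nM, but it differs in other places too, so that gap cannot be credited to the acetyl alone. A modest fall in the number in this assay is therefore expected. The expected change is a 2.5-fold lower number from compound 1 to compound 4 (0.39 log units; beyond the scatter). The estimate for compound 4 is 10000 nM, with an expected range of 3000 nM to 28000 nM.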

Compound 4, half-maximal inhibitory concentration: 2700 nM
Beside the measured number, compound 4's estimate is 3.7-fold (0.57 log units) above it; measured number outside the range, below it.
By their numbers in this assay, from the lowest: compounds 3 and 4 (each within the scatter of the next); then compounds 1 and 2 (each within the scatter of the next).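

In this assay there is a 9.1-fold lower number from compound 1 to compound 4 (0.96 log units; beyond the scatter) from this single acetyl on the oxygen of the hydroxymethyl. This shows that one change at this position, on its own, can move the number beyond the scatter, which the methyl step on another oxygen, a 1.1-fold higher number from compound 1 to compound 2 (0.06 log units; within the scatter), did not do. Nothing measured here explains why the acetyl has this effect. The compounds shown leave open whether the effect is specific to the acetyl or extends to a longer chain such as butanoyl, and how an amine in place of the hydroxy would compare.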